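Chain lengthening on the amine of compound 1

This account rests on a few compounds, and the source may have more. Where it says the series, first, only, none or still open, it means among the compounds named here.

Compound 1 `CCNCc1ccc(Cl)c(-c2ccccc2OC)c1` is one of three compounds of the shared core measured in an assay on isolated protein for binding affinity to 5-hydroxytryptamine receptor 3A (Homo sapiens); on this read-out higher numbers stand for weaker inhibition and lower numbers for stronger inhibition. In this assay compound 1 gives > 10000 nM, which is a limit and not a number. Compound 2 `CCN(CC)Cc1ccc(Cl)c(-c2ccccc2OC)c1` also sits at a limit, giving > 10000 nM in this assay. Compound 3 `COc1ccccc1-c1cc(C2CCN(C)C2)ccc1Cl` gives 420 nM in this assay. Compound 1 thus stands at the limit of > 10000 nM in this assay, at which 2 of the 3 values shown sit, alongside compound 2.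

Compound 4 `CCCNCc1ccc(Cl)c(-c2ccccc2OC)c1` differs from compound 1 by methyl in place of hydrogen on a saturated chain carbon, two bonds along the chain from an amine nitrogen. For the measured compounds named here, the only measured step on the amine is a step that the two limits leave unreadable from compound 1 to compound 2. The large steps of an at least 23-fold lower number from compound 1 to compound 3 (1.37 log units; beyond the scatter) and an at least 23-fold lower number from compound 2 to compound 3 (1.37 log units; beyond the scatter) exchange the whole amine-bearing group and say nothing about a longer chain on the nitrogen. Going by the values given here, no measured step sets a size or a direction for this change, and a number for compound 4 may again not appear. Compound 4 is expected to give about 20000 nM, within 5000 nM to 80000 nM, most probably once more as a limit. The estimated step that the limit leaves unreadable from compound 1 to compound 4 cannot be read against a limit.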

Compound 4, inhibition constant: > 10000 nM
Compound 4: a limit, no number (the forecaster's own chance of this, stated with the estimate: 80%); the middle value is on the limit's open side.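

Going from ethylamino to propylamino in this assay leaves compound 4 at a limit, not a number, so a longer chain on the nitrogen brings no measurable binding at this position. The steps from compound 1 and from compound 2 to compound 4 cannot be read, and the amines on this carbon now share one edge of the read-out: the limit of > 10000 nM in this assay, at which 3 of the 4 values shown sit. For the compounds shown here, the only readable step, an at least 23-fold higher number from compound 3 to compound 4 (1.37 log units; beyond the scatter), exchanges the whole amine-bearing group, so it extends the contrast with 1-methylpyrrolidin-3-yl to a third open-chain amine and says nothing about chain length itself.

From the compounds shown here alone, whether a butylamino or a dimethylamino group at this place would give a number remains open. Also open, going by these compounds, is which feature of the 1-methylpyrrolidin-3-yl group in compound 3 separates it from the open-chain amines.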